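The source may hold more compounds than are shown below. What is called first, only, known or untested is meant among the compounds shown, and "the series" means these compounds.

Measured compounds:
compound 1 `O=C(Nc1cc(C(F)(F)F)ccc1N1CCCCC1)c1ccccc1` — "not active" (no number reported)
compound 2 `O=C(Nc1cc(C(F)(F)F)ccc1NC1CCCCC1)c1ccncc1` — 80900 nM
compound 3 `CCN(CC)c1ccc(C(F)(F)F)cc1NC(=O)c1ccncc1` — "not active" (no number reported)

In a functional assay on Jurkat cells (Homo sapiens) for cytotoxicity, read by MTT assay, with a stated time of 48 h (a higher number here means a weaker inhibitor, a lower number a stronger inhibitor), compound 1 gives "not active" (no number reported), so it has no single number to stand on, and compound 3 likewise gives "not active" (no number reported). Only compound 2 yields a number in this assay, and compound 2 gives 80900 nM, a very weak inhibition. Compound 4 `O=C(Nc1cc(C(F)(F)F)ccc1N1CCCC1)c1ccccc1` has not yet been measured; it differs from compound 1 by pyrrolidin-1-yl in place of piperidin-1-yl on an aromatic carbon. Among the compounds with values here, no pair of measured compounds shows this kind of change, so its direction cannot be read from the data. Given that compound 1 gave no number, the change is expected to move this assay little, if at all, beyond the scatter. Compound 4 is therefore expected near 100000 nM, within 30000 nM to 300000 nM, and may again be reported without a number.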

Compound 4, half-maximal inhibitory concentration: "not active" (no number reported)
Nothing numeric was reported for compound 4, so the estimate cannot be set against anything.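

Neither compound 1 nor compound 4 has a number in this assay, so no step can be read between them. As far as these compounds go, whether replacing piperidin-1-yl with pyrrolidin-1-yl changes activity stays open, and no other evidence bears on this result.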